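Methoxy to hydroxy on the chlorophenyl arm

The source may hold more compounds than are shown below. What is called first, only, known or untested is meant among the compounds shown, and "the series" means these compounds.

Among the measured compounds shown here, in a functional assay on Hs-578T cells (Homo sapiens) for inhibition, read by sulforhodamine B assay, with a stated time of 48 h (a lower number here means a stronger inhibitor of growth, a higher number a weaker inhibitor of growth), compound 1 `O=C(Nc1cccc(-n2cc(-c3ccncc3)c(-c3ccc(Cl)c(O)c3)n2)c1)Nc1cccc(C(F)(F)F)c1` gives 3310 nM and compound 2 `O=C(Nc1cccc(-n2cc(-c3ccncc3)c(-c3ccc(Cl)c(O)c3)n2)c1)Nc1ccc(Cl)c(Cl)c1` gives 785 nM; the one measured step, a 4.2-fold lower number from compound 1 to compound 2 (0.62 log units; beyond the scatter), swaps the aryl group on the urea nitrogen and leaves the oxygen substituent untouched. Compound 3 `COc1cc(-c2nn(-c3cccc(NC(=O)Nc4ccc(Cl)c(C(F)(F)F)c4)c3)cc2-c2ccncc2)ccc1Cl` gives 1320 nM, the second highest of the three numbers, within the scatter of compound 2 and beyond the scatter below compound 1. Compound 4 `O=C(Nc1cccc(-n2cc(-c3ccncc3)c(-c3ccc(Cl)c(O)c3)n2)c1)Nc1ccc(Cl)c(C(F)(F)F)c1` differs from compound 3 by hydrogen in place of methyl on an oxygen on an aromatic ring. No measured pair separates methoxy from hydroxy, so no step shown bears directly on this change; compound 2 carries the hydroxy but with a different urea aryl group. The expected step is a 1.3-fold lower number from compound 3 to compound 4 (0.12 log units; within the scatter), nothing beyond the scatter. Compound 4 is therefore expected to give 1000 nM, within a range from 400 nM to 2500 nM.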

Compound 4, concentration for 50% growth inhibition: 797 nM
The estimate for compound 4 lay 1.3-fold (0.10 log units) above the measured number; the measured number falls inside the stated range.
By their numbers in this assay, from the lowest: compounds 2, 4 and 3 (each within the scatter of the next); then compound 1.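

In this assay, the first direct read of hydrogen in place of methyl on this oxygen, a 1.7-fold lower number from compound 3 to compound 4 (0.22 log units; within the scatter), stays within the scatter, so methoxy and hydroxy are not separated with this urea aryl group. With hydroxy held constant, trifluoromethyl in place of chloro gives a 1.0-fold higher number from compound 2 to compound 4 (0.01 log units; within the scatter), also within the scatter, whereas chloro in place of hydrogen gives a 4.2-fold lower number from compound 1 to compound 4 (0.62 log units; beyond the scatter), beyond it. Nothing available gives a reason for these readings.

On these data alone, the methoxy-to-hydroxy comparison rests on a single pair, so its behaviour with other urea aryl groups remains open. Also open, as far as these compounds go, is how a longer chain such as ethoxy, or an amine, would read on this aromatic carbon.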